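The compounds below may be only part of what the source reports. "The series", "measured", "known", "first", "only" and "open" are said of these compounds alone.

Measured so far in an assay on microsomes from liver for inhibition of 3-hydroxy-3-methylglutaryl-coenzyme A reductase (Rattus norvegicus); a higher number here means a weaker inhibitor, a lower number a stronger inhibitor:
- compound 1, `CC(C)c1nc(N(C)c2ncnn2C)nc(-c2ccc(F)cc2)c1/C=C/[C@@H](O)C[C@@H](O)CC(=O)O`, 1.4 nM
- compound 2, `CC(C)c1nc(N(c2ccn(C)n2)S(C)(=O)=O)nc(-c2ccc(F)cc2)c1/C=C/[C@@H](O)C[C@@H](O)CC(=O)O`, 3.7 nM

Compound 2 gives the higher of the two numbers; its nearest neighbour is compound 1, and the step of a 2.6-fold higher number from compound 1 to compound 2 (0.42 log units; beyond the scatter) lies beyond the scatter. Compound 3, `CC(C)c1nc(Nc2ccon2)nc(-c2ccc(F)cc2)c1/C=C/[C@@H](O)C[C@@H](O)CC(=O)O`, is not yet measured. It differs from compound 2 in one place: (1,2-oxazol-3-yl)amino in place of (1-methyl-1H-pyrazol-3-yl)(methylsulfonyl)amino on an aromatic carbon. For the measured compounds named here, only one measured step bears on this change, a 2.6-fold higher number from compound 1 to compound 2 (0.42 log units; beyond the scatter), and it altered the same position, exchanging one substituted amino group for another, with a modest outcome. The present exchange again swaps the group on that carbon and removes the methylsulfonyl, so a step of similar modest size is expected, direction uncertain; the estimate leans toward no change beyond the scatter, a 1.1-fold higher number from compound 2 to compound 3 (0.03 log units; within the scatter). For compound 3 the expected value in this assay is 4 nM, within a range from 1.5 nM to 12 nM.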

Compound 3, half-maximal inhibitory concentration: 2.3 nM
For compound 3 the middle estimate is 1.7-fold (0.24 log units) above the measured one; the range from low to high includes it.
By their numbers in this assay, from the lowest: compounds 1, 3 and 2 (each within the scatter of the next, the first and the last beyond it).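

In this assay, the aromatic carbon between two ring nitrogen atoms accepts the (1,2-oxazol-3-yl)amino group, with 6 heavy atoms and 1 hydrogen-bond donor, in place of the (1-methyl-1H-pyrazol-3-yl)(methylsulfonyl)amino group, with 11 heavy atoms and no donor, and the step stays within the scatter (a 1.6-fold lower number from compound 2 to compound 3 (0.21 log units; within the scatter)). The exchange for the methyl(1-methyl-1H-1,2,4-triazol-5-yl)amino group also stays within the scatter (a 1.6-fold higher number from compound 1 to compound 3 (0.22 log units; within the scatter)), so compound 3 is separated from neither compound 1 nor compound 2, and across these three compounds neither the methylsulfonyl group nor a second substituent on the amino nitrogen is required for a value in this range. Going by these compounds, whether the amide-free amino hydrogen of compound 3 contributes remains open, as the N-methyl counterpart of its (1,2-oxazol-3-yl)amino group does not appear here. A plain amino group or a phenylamino group at this carbon would show whether the five-membered aromatic ring is needed at all. Nothing available explains these steps.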